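Ester size and para-aryl substituent on the shared core

The source may hold more compounds than are shown below. What is called first, only, known or untested is meant among the compounds shown, and "the series" means these compounds.

Compound 1 `COC(=O)c1nc(-c2ccc[nH]2)n(-c2ccc(F)cc2)n1` gives 9010 nM in a functional assay on Jurkat cells (Homo sapiens) for inhibition, read by MTT assay, with a stated time of 72 h; a higher number here means a weaker inhibitor of growth, a lower number a stronger inhibitor of growth. Compound 2 `COC(=O)c1nc(-c2ccc[nH]2)n(-c2ccc(C(F)(F)F)cc2)n1` sits at the assay limit, > 100000 nM. Compound 3 `CCOC(=O)c1nc(-c2ccc[nH]2)n(-c2ccc(C(F)(F)F)cc2)n1` likewise sits at the assay limit, > 100000 nM. This is the limit of > 100000 nM in this assay, at which 2 of the 3 values shown sit; compound 3 therefore has no number of its own in this assay, only a ceiling. The step of an at least 11-fold higher number from compound 1 to compound 2 (1.04 log units; beyond the scatter) is the only readable one in the set, while the step that the two limits leave unreadable from compound 2 to compound 3 cannot be sized. Compound 4 `CCOC(=O)c1nc(-c2ccc[nH]2)n(-c2ccc(F)cc2)n1` differs from compound 3 by fluoro in place of trifluoromethyl on an aromatic carbon, the reverse of the readable step. A large fall is expected for compound 4, an at least 10-fold lower number from compound 3 to compound 4 (1.00 log units; beyond the scatter), bringing it back toward the number of compound 1, 9010 nM. Compound 4 is therefore estimated at 10000 nM, within 3000 nM to 40000 nM.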

Compound 4, concentration for 50% growth inhibition: > 100000 nM
Compound 4: only a limit was reported; the forecaster's own chance of this, stated with the estimate: 15%; middle value at least 10-fold (1.00 log units) away from the limit.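

In this assay, the methyl in place of hydrogen on the chain carbon bound to the oxygen now has a readable size with fluoro held constant: an at least 11-fold higher number from compound 1 to compound 4 (1.04 log units; beyond the scatter). This change alone therefore carries the fluoro compound to the limit, and fluoro in place of trifluoromethyl restores no number on the ethyl ester. The steps joining compound 2, compound 3 and compound 4 cannot be read: the limit of > 100000 nM in this assay, at which 3 of the 4 values shown sit.

Any difference hidden at the limit between compound 3 and compound 4 stays open. So does whether a carboxylic acid or an amide in place of the ester returns a measurable number.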